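Fluoro to Methoxy: Expected Half-Life of Compound 3

This account rests on a few compounds, and the source may have more. Where it says the series, first, only, none or still open, it means among the compounds named here.

Among the measured compounds shown here, compound 2 `O=C(NCc1ccccc1F)N1C(=O)c2ccccc2S1(=O)=O` gives 0.598 h in a physicochemical assay for pharmacokinetics (on this read-out lower numbers stand for a shorter-lived compound and higher numbers for a longer-lived compound), and compound 1 `O=C(NCc1cccs1)N1C(=O)c2ccccc2S1(=O)=O`, which gives 0.365 h, is not separated from it beyond the scatter: the only measured step, a 1.6-fold higher number from compound 1 to compound 2 (0.21 log units; within the scatter), swaps one ring for another. Compound 3 `COc1ccccc1CNC(=O)N1C(=O)c2ccccc2S1(=O)=O` differs from compound 2 by methoxy in place of fluoro on an aromatic carbon. For the measured compounds named here, no measured step changes a small group on this ring, so there is no direct guide, and with the one known step within the scatter no movement beyond it is expected. Compound 3 is therefore expected to give 0.6 h, between 0.3 h and 1.2 h, an expected step of a 1.0-fold higher number from compound 2 to compound 3 (0.00 log units; within the scatter).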

Compound 3, half-life: 1.12 h
Compound 3: the middle estimate sits 1.9-fold (0.27 log units) below what was measured; the range from low to high includes it.
By their numbers in this assay, from the lowest: compounds 1, 2 and 3 (each within the scatter of the next, the first and the last beyond it).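

In this assay, the step with methoxy in place of fluoro on this aromatic carbon, ortho to a large group, is a 1.9-fold higher number from compound 2 to compound 3 (0.27 log units; within the scatter) and stays within the scatter, so the two groups cannot be told apart here. The ring change now gives a clear result, with 2-methoxyphenyl in place of thiophen-2-yl producing a 3.1-fold higher number from compound 1 to compound 3 (0.49 log units; beyond the scatter) and passing beyond the scatter, though only modestly. No measurement offered here explains either step.

As far as these compounds go, it remains open how an ethoxy group or an amine would behave in this place. Whether a longer chain to the ring would preserve the gap from compound 1 is also unknown.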